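Bromo for Butoxy on a Second Core

The source may report more compounds than this note shows. Statements on the series, on what has been measured and on what is new or still open speak of the compounds shown alone.

Compound 1 `CCCCOc1ccc(-c2nc3ncccn3c2NC(C)(C)CC(C)(C)C)cc1` gives 29000 nM in a toxicity assay on A549 cells (Homo sapiens) for cytotoxicity, read by luminescence and CellTiter-Glo, with a stated time of 48 h; a lower number here means that less compound is tolerated, a higher number that more compound is tolerated. Compound 2 `CCCCOc1ccc(-c2c(NC(C)(C)CC(C)(C)C)nc3ncccn23)cc1` gives 49000 nM in this assay. Compound 3 `CC(C)(C)CC(C)(C)Nc1c(-c2ccc(Br)cc2)nc2ncccn12` gives 32000 nM in this assay.

Compounds 1 and 2 are built from the same atoms joined differently; the difference between the two cores is not broken down here. All three measured values lie within the usual scatter of one another, so no order among them is claimed. Compound 3 differs from compound 1 by bromo in place of butoxy on an aromatic carbon; the step was a 1.1-fold higher number from compound 1 to compound 3 (0.04 log units; within the scatter). Compound 4 `CC(C)(C)CC(C)(C)Nc1nc2ncccn2c1-c1ccc(Br)cc1` carries the same change on the core of compound 2: bromo in place of butoxy on an aromatic carbon. The step from compound 2 to compound 4 is therefore expected to be a 1.1-fold higher number from compound 2 to compound 4 (0.03 log units; within the scatter), resting on a 1.1-fold higher number from compound 1 to compound 3 (0.04 log units; within the scatter). Compound 4 is estimated at 52000 nM in this assay, expected between 25000 nM and 110000 nM.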

Compound 4, half-maximal cytotoxic concentration: > 100000 nM
Compound 4 ended at the assay's limit (the forecaster's own chance of this, stated with the estimate: 25%); middle value at least 1.9-fold (0.28 log units) from the limit.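

Compound 4 stands at a limit of this assay, not at a number: > 100000 nM. Read from that limit, bromo in place of butoxy on an aromatic carbon gave an at least 2.0-fold higher number from compound 2 to compound 4 (0.30 log units; that floor lies within the scatter). This shows that the change left compound 4 at the limit on the core of compound 2, but not whether the step carries over unchanged from one core to the other: the same change on two cores in this assay, a 1.1-fold higher number (0.04 log units; within the scatter) from compound 1 to compound 3 and an at least 2.0-fold higher number (0.30 log units; that floor lies within the scatter) from compound 2 to compound 4; the limit leaves it open whether they differ

The compounds shown leave open how either core would respond to an amine, a carboxylic acid or a shorter chain in place of butoxy on that aromatic carbon. With a single such change on each core, they also leave open whether any other group would give steps that match across the two cores.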